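A few compounds are considered here, and "the series" means these few. Any claim that something is new, unique, unknown or untested is made for them only; others in the source may bear on it.

Values measured so far in an ADME assay on the whole organism (strain Zucker) for pharmacokinetics, with Rattus norvegicus as the target, with a stated time of 14 days, at a dose of 3 mg/kg by the oral route; a higher number here means more compound in the circulation at the dose given, a lower number less compound in the circulation:
- compound 1 (`Cn1c(COc2cccc(C(=O)O)c2)nc2cnc(Oc3ccc4c(c3)CCC4)cc21`): 987 nM
- compound 2 (`Cn1c(COc2cccc(C(=O)O)c2)nc2ccc(Oc3ccc(Cl)cn3)cc21`): 161 nM

Compound 2 stands lowest of the two, and compound 1 lies beyond the scatter above it. Compound 3 (`Cn1c(COc2cccc(C(=O)O)c2)nc2ccc(Oc3ncc(Cl)cc3F)cc21`) differs from compound 2 by fluoro in place of hydrogen on an aromatic carbon. Going by the values given here, no measured pair shows this change in this assay and the two values give no guide to its direction. No step beyond the scatter is therefore expected. The expected change is a 1.2-fold higher number from compound 2 to compound 3 (0.09 log units; within the scatter) and it lies within the scatter. Compound 3 is estimated at 200 nM with an expected range from 70 nM to 550 nM on this reading.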

Compound 3, maximal plasma concentration: 1050 nM
Estimate against measurement, compound 3: 5.3-fold (0.72 log units) below; the measured number lies above the stated range.
By their numbers in this assay, from the lowest: compound 2; then compounds 1 and 3 (each within the scatter of the next).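

Going from 5-chloropyridin-2-yl to 5-chloro-3-fluoropyridin-2-yl gives a 6.5-fold higher number from compound 2 to compound 3 (0.81 log units; beyond the scatter) in this assay, the first step seen between compounds that differ in one place. It shows that at this position, ortho to a large group and two atoms from the ring nitrogen, a single fluoro in place of hydrogen moves the number beyond the scatter. Nothing measured here accounts for the step.

The compounds shown leave open whether a methyl or a nitrile at this position would move the number as fluoro does. They also leave open whether fluoro elsewhere on this ring would have a similar effect.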